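Swapping a cyclohexyl for a furan-bearing group on a urea

This account rests on a few compounds, and the source may have more. Where it says the series, first, only, none or still open, it means among the compounds named here.

Measured so far:
Compound 1, `Cc1nc(N)sc1CCCN/C(N)=N/C(=O)NC1CCCCC1`, 170 nM
Compound 2, `Cc1nc(N)sc1CCCN/C(N)=N/C(=S)NC(c1ccccc1)c1ccccc1`, 603 nM
Compound 3, `Cc1nc(N)sc1CCCN/C(N)=N/C(=S)N[C@H](C)c1ccccc1`, 115 nM

All three share one core and differ only in the group carried on the terminal nitrogen. In an assay on membranes from Sf9 cells for displacement of a labelled ligand from histamine H2 receptor (Homo sapiens), read by scintillation counting, with a stated time of 60 min (a lower number here means a stronger inhibitor, a higher number a weaker inhibitor), compound 1 gives 170 nM, the second highest of the three numbers. Compound 3 gives 115 nM, and the gap between compound 1 and compound 3 lies within the usual scatter. Compound 2 gives 603 nM, a higher number that lies beyond the scatter, so compound 2 is the weaker inhibitor of that pair.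

Compound 4, `Cc1nc(N)sc1CCCN/C(N)=N/C(=O)NC(C)c1ccco1`, has not yet been measured. It differs from compound 1 in one place: 1-(furan-2-yl)ethyl in place of cyclohexyl on an amide-type nitrogen. Going by the values given here, no measured pair shows this exact change, so the size of the step can only be guessed. The change keeps the urea and its hydrogen and exchanges one ring for another, which looks most like a small step in this assay, with no clear direction beyond the scatter. Compound 4 is therefore expected to land near compound 1, at about 150 nM, with a range from 50 nM to 500 nM. The step from compound 1 to compound 4 is expected to be a 1.1-fold lower number from compound 1 to compound 4 (0.05 log units; within the scatter), partly because compound 3, carrying a related one-carbon-branched group, gives 115 nM.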

Compound 4, inhibition constant: 31.6 nM
Compound 4: the middle estimate sits 4.7-fold (0.68 log units) above what was measured, outside the stated range (below it).
By their numbers in this assay, from the lowest: compound 4; then compounds 3 and 1 (each within the scatter of the next); then compound 2.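

In this assay, the group on the amide-type nitrogen of the urea clearly affects the result: 1-(furan-2-yl)ethyl in place of cyclohexyl gives a 5.4-fold lower number from compound 1 to compound 4 (0.73 log units; beyond the scatter). Going by these compounds alone, the earlier compounds offered no pair differing in one place, so this is the first step at this position whose size can be read. The change replaces a six-membered non-aromatic ring of carbon only with a five-membered aromatic ring with one hetero atom and also adds a methyl-bearing carbon, so this single step cannot show which part matters.

The compounds shown leave that question open, and a furan-2-ylmethyl group or a 1-cyclohexylethyl group on the same urea would help separate the two parts. Nothing available gives a measured reason for the step.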